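The source may hold more compounds than are shown below. What is called first, only, known or untested is meant among the compounds shown, and "the series" means these compounds.

Within the data shown here, in a functional assay on NCI-H1993 cells (Homo sapiens) for inhibition, read by CCK-8 assay, with a stated time of 72 h (a lower number here means a stronger inhibitor, a higher number a weaker inhibitor), three compounds built on a shared core have numbers so far. Compound 1 `CC(NC/N=C/c1cn[nH]c1)c1ccc2ncccc2c1` gives 519 nM, compound 2 `CC(NC/N=C/c1ccncc1)c1ccc2ncccc2c1` gives 614 nM, and compound 3 `CC(NC/N=C/c1ccccc1)c1ccc2ncccc2c1` gives 1220 nM. Compound 3, which carries phenyl, differs beyond the scatter from only one of the others: the record shows a 2.4-fold higher number from compound 1 to compound 3 (0.37 log units; beyond the scatter), a modest step, while a 2.0-fold higher number from compound 2 to compound 3 (0.30 log units; within the scatter) stays within the scatter, as does a 1.2-fold higher number from compound 1 to compound 2 (0.07 log units; within the scatter).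

Compound 4 `CC(NC/N=C/C1=CCNCC1)c1ccc2ncccc2c1` changes the same place, on a carbon with a double bond to nitrogen: a group of 6 heavy atoms (5 carbon, 1 nitrogen; one six-membered non-aromatic ring with 1 hetero atom) in place of a group of 6 heavy atoms (6 carbon; one six-membered aromatic ring of carbon only), on a carbon with a double bond to nitrogen. Among the measured compounds shown here, no measured compound has a non-aromatic ring there, so the two steps that end at compound 3 are only indirect guides. Read in reverse, they suggest a small move to a lower number in this assay, perhaps none beyond the scatter. The estimated step is a 1.7-fold lower number from compound 3 to compound 4 (0.24 log units; within the scatter). For compound 4 the expected value is 700 nM, within an estimated range of 250 nM to 1800 nM.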

Compound 4, half-maximal inhibitory concentration: 2660 nM
Beside the measured number, compound 4's estimate is 3.8-fold (0.58 log units) below it; the measured number lies above the stated range.
By their numbers in this assay, from the lowest: compounds 1, 2 and 3 (each within the scatter of the next, the first and the last beyond it); then compound 4.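

On a carbon with a double bond to nitrogen, the non-aromatic ring of compound 4 gives a higher number in this assay than each aromatic ring shown (a 2.2-fold higher number from compound 3 to compound 4 (0.34 log units; beyond the scatter); a 4.3-fold higher number from compound 2 to compound 4 (0.64 log units; beyond the scatter); a 5.1-fold higher number from compound 1 to compound 4 (0.71 log units; beyond the scatter)), which makes compound 4 the weakest of the four. Compound 3, whose phenyl has no hydrogen-bond donor or acceptor, stands at a lower number than compound 4, whose group has one of each, so these counts alone do not order the compounds at this position. No measurement at hand accounts for this result.

Compound 4 differs from compound 3 in both its ring nitrogen and its loss of aromaticity, and the compounds shown do not separate these two changes. From the compounds shown here alone, how a piperidin-4-yl ring or an all-carbon cyclohexenyl ring would read at this position remains open.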